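Trimming an Aryl Tail on a Weak Raji Inhibitor

The compounds below may be only part of what the source reports. "The series", "measured", "known", "first", "only" and "open" are said of these compounds alone.

Compound 2 `C=CC(=O)Nc1cccc(Nc2ncnc(Nc3ccc(-c4ccc(C)nc4)cc3)n2)c1` sits at the upper end of the two numbers available in a functional assay on Raji cells (Homo sapiens) for antiproliferative activity, read by CCK-8 assay, with a stated time of 24 h (on this read-out higher numbers stand for weaker inhibition and lower numbers for stronger inhibition), where compound 2 gives 13800 nM. Its nearest neighbour, compound 3 `C=CC(=O)N1CCc2ccc(Nc3ncnc(Nc4ccc(C(=O)N5CCCCC5)cc4)n3)cc21`, gives 2840 nM in this assay, a gap beyond the usual scatter. Compound 1 `C=CC(=O)Nc1cccc(Nc2nc(Cl)nc(Nc3ccc(OCCOC)cc3)n2)c1` gives "not determined" (no result reported) in this assay, so it carries no result there. Compound 4 `C=CC(=O)Nc1cccc(Nc2ncnc(Nc3ccc(OC)cc3)n2)c1` differs from compound 2 in one place: methoxy in place of 6-methylpyridin-3-yl on an aromatic carbon. Going by the values given here, no pair of measured compounds isolates this change, so the step has no direct precedent in the set. Among the compounds with values here, with a single anchor and no comparable pair, only a modest move is expected, its direction uncertain. The expected step of a 1.4-fold lower number from compound 2 to compound 4 (0.14 log units; within the scatter) is small. Compound 4 is therefore estimated at 10000 nM, within a range from 3000 nM to 35000 nM.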

Compound 4, half-maximal inhibitory concentration: 14500 nM
Compound 4: the middle estimate sits 1.5-fold (0.16 log units) below what was measured; low and high end bracket the measured number.
By their numbers in this assay, from the lowest: compound 3; then compounds 2 and 4 (each within the scatter of the next).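

In this assay, methoxy in place of 6-methylpyridin-3-yl, on an aromatic carbon para to a large group, gives a 1.1-fold higher number from compound 2 to compound 4 (0.02 log units; within the scatter) and so leaves the read-out unmoved. At this position, then, the six-membered aromatic ring of the larger group can be removed without a change beyond the scatter. Nothing available explains why the two groups read alike. On these data alone, whether an amine, a carboxylic acid or a longer alkyl chain at this position would shift the number remains open, and so does whether any group placed here can.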